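The source may report more compounds than this note shows. Statements on the series, on what has been measured and on what is new or still open speak of the compounds shown alone.

Working notes on the series. In a functional assay on U-87MG ATCC cells for antiproliferative activity against U-87 MG (Homo sapiens), read by MTT assay, with a stated time of 48 h, tested at 5 uM (on this read-out lower numbers stand for a stronger effect and higher numbers for a weaker effect at the one concentration tested), compound 3 `Cc1nc(-c2ccc(Cl)cc2)sc1C(=O)CSc1nc(-c2ccc(Cl)c(Cl)c2)c(C#N)c(=O)[nH]1` gives 101%, the highest of the three numbers; compound 2 `COc1ccc(-c2nc(SCC(=O)c3sc(-c4ccccc4)nc3C)[nH]c(=O)c2C#N)cc1` gives 97.3%, within the scatter of compound 3, while compound 1 `Cc1nc(-c2ccc(Cl)cc2)sc1C(=O)CSc1nc(-c2ccccc2)c(C#N)c(=O)[nH]1` gives 88.9%. Going by the values given here, the only step recorded at this position, a number 12.1 percentage points higher from compound 1 to compound 3 (beyond the scatter), is modest and beyond the scatter. Compound 4 `COc1ccc(-c2nc(SCC(=O)c3sc(-c4ccc(Cl)cc4)nc3C)[nH]c(=O)c2C#N)cc1` differs from compound 3 in one place: 4-methoxyphenyl in place of 3,4-dichlorophenyl on an aromatic carbon. Among the compounds with values here, no measured step covers this change; compound 2, which carries 4-methoxyphenyl at the same position, sits within the scatter of compound 3. Compound 4 is therefore expected to change little, with a number 4 percentage points lower from compound 3 to compound 4 (within the scatter) likely within the scatter. The estimate for compound 4 in this assay is 97%, range 87% to 105%.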

Compound 4, a percentage reported as activity, at one concentration (the size of the read-out at that concentration, not a potency): 92.1%
Estimate against measurement, compound 4: 4.9 percentage points above; the range from low to high includes it.
By their numbers in this assay, from the lowest: compounds 1, 4, 2 and 3 (each within the scatter of the next, the first and the last beyond it).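

In this assay, 4-methoxyphenyl in place of 3,4-dichlorophenyl on this aromatic carbon now has a measured step: a number 8.9 percentage points lower from compound 3 to compound 4 (within the scatter). With methoxy in place of hydrogen, the same position gives a number 3.2 percentage points higher from compound 1 to compound 4 (within the scatter), and chloro in place of hydrogen on the other aromatic ring gives a number 5.2 percentage points lower from compound 2 to compound 4 (within the scatter), so none of these three single changes moves the number beyond the scatter. No evidence on the cause of these small steps is available.

Open is whether an amine or a carboxylic acid on the phenyl at this position would give a number beyond the scatter of these compounds. Also open, going by these compounds, is how these steps would read at other concentrations.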